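A few compounds are considered here, and "the series" means these few. Any claim that something is new, unique, unknown or untested is made for them only; others in the source may bear on it.

Three compounds of the shared core have been run in an ADME assay on PC-3 cells (Homo sapiens) for cytotoxicity, read by WST assay, tested at 100 uM; a higher number here means more inhibition at the concentration tested (going by the name of the read-out), a lower number less inhibition. Compound 1 `O=C(Nc1ccc(Cl)cc1)C1CCCN(C(=O)c2cccc([N+](=O)[O-])c2)C1` gives 0%. Compound 2 `CCc1cccc(NC(=O)C2CCCN(C(=O)c3cc(C(F)(F)F)cc(C(F)(F)F)c3)C2)c1` gives 0%, level with compound 1 at the digits recorded, and together these two are the lowest of the three numbers. Compound 3 `CS(=O)(=O)c1cccc(C(=O)N2CCCC(C(=O)Nc3ccc(Cl)cc3)C2)c1` gives 2%. For the measured compounds named here, the only pair differing in one place is compound 1 and compound 3, where methylsulfonyl in place of nitro on an aromatic carbon gives a number 2 percentage points higher from compound 1 to compound 3 (within the scatter), a step inside the scatter. Compound 2 and compound 3 differ in more than one place; their two values sit two points apart.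

Compound 4 `C=CCOc1cccc(NC(=O)C2CCCN(C(=O)c3cc(C(F)(F)F)cc(C(F)(F)F)c3)C2)c1` is not yet measured. It differs from compound 2 as allyloxy in place of ethyl on an aromatic carbon, allyloxy entering where ethyl left. Going by the values given here, no measured step touches this part of the structure, so the change itself carries no precedent here. Among the compounds with values here, what the series shows is that every tested variant sits at the floor of this assay, with the one single-point step, from compound 1 to compound 3, inside the scatter. Compound 4 is therefore expected to stay at that floor, with a number 2 percentage points higher from compound 2 to compound 4 (within the scatter) as the expected step, none beyond the scatter. For compound 4 the estimate in this assay is 2%, between 0% and 12%.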

Compound 4, a percentage reported as inhibition, at one concentration (the size of the read-out at that concentration, not a potency): 0%
Estimate against measurement, compound 4: 2 percentage points above; low and high end bracket the measured number.
By their numbers in this assay, from the lowest: compounds 1, 2, 4 and 3 (each within the scatter of the next).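

In this assay, for the compounds shown here, the change from 3-ethylphenyl to 3-(allyloxy)phenyl gives no change at the digits printed from compound 2 to compound 4 (within the scatter), the first reading at this position, on an aromatic carbon meta to a large group. Allyloxy has 4 heavy atoms against the 2 of ethyl and adds a double bond outside aromatic rings and a hydrogen-bond acceptor, yet this single change leaves the read-out within the scatter, as did the change from nitro to methylsulfonyl in a different part of the structure. No available evidence bears on this result, so the flat step stands as an observation only.

With compound 2 at 0% and compound 4 at 0%, both sit at the bottom of the read-out, so the step shows only that allyloxy adds no measurable inhibition at the one concentration tested, and it cannot separate the two compounds any further. Still open, on these data alone, is whether a primary amine, a carboxylic acid or a longer alkoxy chain at this position would lift the number beyond the scatter, or whether this position stays flat across such groups as well.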